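The source may hold more compounds than are shown below. What is called first, only, known or untested is meant among the compounds shown, and "the series" means these compounds.

In a functional assay on A549 cells (Homo sapiens) for cytotoxicity, read by MTT assay, with a stated time of 72 h (on this read-out higher numbers stand for weaker inhibition and lower numbers for stronger inhibition), compound 3 `COc1ccc(/C=C2\CCC/C(=C\c3ccc(OC)c(OC)c3)C2=O)cc1` reports only a limit, > 20000 nM. Compound 4 `COc1ccc(/C=C2\CCC/C(=C\c3cc(Cl)cc(Cl)c3)C2=O)cc1OC` carries 3,5-dichlorophenyl in place of 4-methoxyphenyl on a double-bonded chain carbon bound to a double-bonded ring carbon. Two measured neighbours bear on this change. Compound 1 `COc1ccc(/C=C2\CCC/C(=C\c3cccc(Br)c3)C2=O)cc1OC`, with 3-bromophenyl at that place, gives 12800 nM, and compound 2 `COc1cccc(/C=C2\CCC/C(=C\c3ccc(OC)c(OC)c3)C2=O)c1`, with 3-methoxyphenyl, gives 6700 nM. These two lie within the scatter of each other. The data show an at least 2.9-fold higher number from compound 2 to compound 3 (0.47 log units; beyond the scatter), while an at least 1.5-fold higher number from compound 1 to compound 3 (0.19 log units; that floor lies within the scatter) has a floor within the scatter. Leaving 4-methoxyphenyl is therefore expected to lower the number modestly, towards compound 1 at 12800 nM. The expected step is an at least 2.0-fold lower number from compound 3 to compound 4 (0.30 log units; that floor lies within the scatter). For compound 4 the estimated value is 10000 nM, with an expected range of 4500 nM to 20000 nM.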

Compound 4, half-maximal inhibitory concentration: 5500 nM
For compound 4 the middle estimate is 1.8-fold (0.26 log units) above the measured one; measured number inside the range.
By their numbers in this assay, from the lowest: compounds 4, 2 and 1 (each within the scatter of the next, the first and the last beyond it). At a limit, above all of these: compound 3.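

At this place, on a double-bonded chain carbon bound to a double-bonded ring carbon, 3,5-dichlorophenyl gives (an at least 3.6-fold lower number from compound 3 to compound 4 (0.56 log units; beyond the scatter)) against 4-methoxyphenyl. It also separates from 3-bromophenyl (a 2.3-fold lower number from compound 1 to compound 4 (0.37 log units; beyond the scatter)), but not from 3-methoxyphenyl (a 1.2-fold lower number from compound 2 to compound 4 (0.09 log units; within the scatter)). The number for compound 3 is only a limit, so the first step is a floor: the limit of > 20000 nM in this assay, at which 1 of the 4 values shown sits.

Still open, as far as these compounds go, is whether a single chlorine on this phenyl ring would be enough for the step. From the compounds shown here alone, it is equally open whether an amine or a carboxylic acid in place of the chlorines would hold this level.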